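Moving a Phenyl Substituent on a Triazole Core

The source may hold more compounds than are shown below. What is called first, only, known or untested is meant among the compounds shown, and "the series" means these compounds.

Compound 1 `CC1(C)[C@H]2CC[C@]1(C)N(Cc1cn(-c3ccccc3O)nn1)C(=O)C2` gives 120 nM in a functional assay on HepG2 cells (Homo sapiens) for inhibition, read by MTT assay, with a stated time of 24 h; a lower number here means a stronger inhibitor, a higher number a weaker inhibitor.
Compound 2 `CC1(C)[C@H]2CC[C@]1(C)N(Cc1cn(-c3ccccc3C#N)nn1)C(=O)C2` gives 180 nM in this assay.
Compound 3 `CC1(C)[C@H]2CC[C@]1(C)N(Cc1cn(-c3ccccc3Br)nn1)C(=O)C2` gives 150 nM in this assay.

Compound 1 has the lowest number of the three, but its neighbours lie close: a 1.5-fold higher number from compound 1 to compound 2 (0.18 log units; within the scatter) and a 1.3-fold higher number from compound 1 to compound 3 (0.10 log units; within the scatter), and between the other two, a 1.2-fold lower number from compound 2 to compound 3 (0.08 log units; within the scatter). None of these three compounds can be set apart from the others on these numbers.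

Compound 4 `CC1(C)[C@H]2CC[C@]1(C)N(Cc1cn(-c3ccc(F)cc3)nn1)C(=O)C2` has not been measured. It differs from compound 1 in one way: 4-fluorophenyl in place of 2-hydroxyphenyl on an aromatic nitrogen. For the measured compounds named here, the two measured steps from compound 1 bear on this only in part, since each of them exchanged one group for another while keeping the ring itself unchanged; no measured step alters the ring in the way seen here. Those steps were small and within the scatter, so a step from compound 1 to compound 4 in this assay is expected to be modest, with a slightly higher number the more likely direction, estimated as a 1.4-fold higher number from compound 1 to compound 4 (0.15 log units; within the scatter). Compound 4 is therefore expected to give about 170 nM in this assay, within the range 70 nM to 420 nM.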

Compound 4, half-maximal inhibitory concentration: 90 nM
Beside the measured number, compound 4's estimate is 1.9-fold (0.28 log units) above it; the measured number falls inside the stated range.
By their numbers in this assay, from the lowest: compounds 4, 1, 3 and 2 (each within the scatter of the next).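

Until now only 2-hydroxyphenyl, 2-cyanophenyl and 2-bromophenyl had been compared on the aromatic nitrogen; 4-fluorophenyl extends that set, and in this assay the readings are a 1.3-fold lower number from compound 1 to compound 4 (0.12 log units; within the scatter), a 1.7-fold lower number from compound 3 to compound 4 (0.22 log units; within the scatter) and a 2.0-fold lower number from compound 2 to compound 4 (0.30 log units; within the scatter). Compound 4 has 0 hydrogen-bond donors and 0 hydrogen-bond acceptors in this group, yet it cannot be set apart from compound 1, so the hydroxy group of 2-hydroxyphenyl is not required for a number in this range. Nothing measured here explains the result.

The group and its place on the phenyl ring change together in this step, so the two cannot be told apart. Going by these compounds, it also remains open whether an amine or a carboxylic acid on that ring would give a step beyond the scatter.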